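Naphthyl for Bromophenyl on a Sulfonamide Amine Scaffold

This account rests on a few compounds, and the source may have more. Where it says the series, first, only, none or still open, it means among the compounds named here.

Compound 1, `COc1ccc(CNCCCNS(=O)(=O)c2cc(C(F)(F)F)cc(C(F)(F)F)c2)cc1OC`: in a functional assay on PANC-1 cells (Homo sapiens) for inhibition, read by MTT assay, with a stated time of 72 h (on this read-out higher numbers stand for weaker inhibition of growth and lower numbers for stronger inhibition of growth), compound 1 gives 18000 nM.
Compound 2, `O=S(=O)(NCCCNCc1ccc(C(F)(F)F)cc1)c1cc(C(F)(F)F)cc(C(F)(F)F)c1`: in this assay compound 2 gives 3200 nM.
Compound 3, `O=S(=O)(NCCCNCc1ccc(Br)cc1)c1cc(C(F)(F)F)cc(C(F)(F)F)c1`: in this assay compound 3 gives 2200 nM.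
Compound 4, `O=S(=O)(NCCCNCc1cccc2ccccc12)c1cc(C(F)(F)F)cc(C(F)(F)F)c1`: not yet measured.

Compound 3 carries the lowest number of the three measured compounds, but its separation from compound 2, a 1.5-fold lower number from compound 2 to compound 3 (0.16 log units; within the scatter), lies within the scatter, so the two cannot be ordered; only against compound 1, an 8.2-fold lower number from compound 1 to compound 3 (0.91 log units; beyond the scatter), does compound 3 stand clearly apart. The step to compound 4 is naphthalen-1-yl in place of 4-bromophenyl on a saturated chain carbon bound to an amine nitrogen. Two measured steps alter the same aryl group at this position, a 5.6-fold lower number from compound 1 to compound 2 (0.75 log units; beyond the scatter) and an 8.2-fold lower number from compound 1 to compound 3 (0.91 log units; beyond the scatter), both modest, while the exchange of the single substituent, a 1.5-fold lower number from compound 2 to compound 3 (0.16 log units; within the scatter), is within the scatter. Within the data shown here, no measured step introduces a fused second ring, so the data offer no direct precedent for this change. The two aryl groups without oxygen substituents cluster together, and compound 4 is expected to stay near them. Compound 4 is therefore estimated at 2000 nM, with a range from 700 nM to 6000 nM. The expected step, a 1.1-fold lower number from compound 3 to compound 4 (0.04 log units; within the scatter), is estimated to remain within the scatter.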

Compound 4, concentration for 50% growth inhibition: 2700 nM
Compound 4: middle estimate off by 1.4-fold (0.13 log units), on the low side; the range from low to high includes it.
By their numbers in this assay, from the lowest: compounds 3, 4 and 2 (each within the scatter of the next); then compound 1.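

In this assay, the place on a saturated chain carbon bound to an amine nitrogen accepts a second fused ring without a readable shift: a 1.2-fold higher number from compound 3 to compound 4 (0.09 log units; within the scatter) and a 1.2-fold lower number from compound 2 to compound 4 (0.07 log units; within the scatter) both lie within the scatter, so naphthalen-1-yl cannot be told apart from 4-bromophenyl or 4-(trifluoromethyl)phenyl. Against 3,4-dimethoxyphenyl the picture is different, with a 6.7-fold lower number from compound 1 to compound 4 (0.82 log units; beyond the scatter) beyond the scatter. Among these compounds, one or two six-membered aromatic rings at this place therefore makes no readable difference, and compound 1 alone stands apart.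

Nothing available explains why these three aryl groups give such similar numbers. From the compounds shown here alone, whether naphthalen-2-yl, a pyridine ring or a cyclohexyl group would stay in this range remains open, as does the outcome of a longer chain in the shared core.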